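Aryl variation on the hydrazone carbon of the shared core

A few compounds are considered here, and "the series" means these few. Any claim that something is new, unique, unknown or untested is made for them only; others in the source may bear on it.

Measured so far:
compound 1, `O=C(CSc1nnc(-c2ccncc2)o1)N/N=C/c1ccc([N+](=O)[O-])cc1`; in a functional assay on SW 1116 cells (Homo sapiens) for cytotoxicity, read by MTT assay, with a stated time of 48 h (a lower number here means a stronger inhibitor, a higher number a weaker inhibitor), compound 1 gives 25800 nM
compound 2, `COc1ccc(/C=N/NC(=O)CSc2nnc(-c3ccncc3)o2)cc1`; in this assay compound 2 gives 20300 nM
compound 3, `O=C(CSc1nnc(-c2ccncc2)o1)N/N=C/c1cccc(F)c1`; in this assay compound 3 gives 26700 nM

The three numbers sit close together. Compound 3 has the largest of them, but neither step to it separates it from the others: from compound 1 the step is a 1.0-fold higher number from compound 1 to compound 3 (0.01 log units; within the scatter), from compound 2 it is a 1.3-fold higher number from compound 2 to compound 3 (0.12 log units; within the scatter). The remaining pair behaves the same way, a 1.3-fold lower number from compound 1 to compound 2 (0.10 log units; within the scatter). Each of these steps swaps only the aryl group on the carbon with a double bond to nitrogen, and none moves the read-out in this assay beyond the scatter.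

The next compound is compound 4, `O=C(CSc1nnc(-c2ccncc2)o1)N/N=C/c1cc(Br)ccc1O`. It differs from compound 3 in the same place: 5-bromo-2-hydroxyphenyl in place of 3-fluorophenyl on a carbon with a double bond to nitrogen. For the measured compounds named here, every measured step that bears on this position, the three just named, stayed within the scatter, so no step beyond the scatter is expected in this assay in either direction, and the added hydroxy group gives no measured precedent that would change this.

Compound 4 is therefore estimated at 23000 nM in this assay, with a range of 9000 nM to 60000 nM. The expected step is a 1.2-fold lower number from compound 3 to compound 4 (0.06 log units; within the scatter).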

Compound 4, half-maximal inhibitory concentration: 8150 nM
Estimate against measurement, compound 4: 2.8-fold (0.45 log units) above; measured number below the stated range.
By their numbers in this assay, from the lowest: compound 4; then compounds 2, 1 and 3 (each within the scatter of the next).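

In this assay the aryl group on the carbon with a double bond to nitrogen can move the read-out after all: the series now holds a 3.3-fold lower number from compound 3 to compound 4 (0.52 log units; beyond the scatter) and a 2.5-fold lower number from compound 2 to compound 4 (0.40 log units; beyond the scatter) and also a 3.2-fold lower number from compound 1 to compound 4 (0.50 log units; beyond the scatter) as steps of a size that the three earlier aryl swaps did not reach. For the compounds shown here, compound 4 therefore has the lowest number of the four compounds on the shared core, and it is also the only one whose aryl group carries a hydrogen-bond donor, so the earlier flat readings held for the 4-nitrophenyl, 4-methoxyphenyl and 3-fluorophenyl groups and not for every aryl group here. No measured evidence accounts for this step.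

The 5-bromo-2-hydroxyphenyl group brings the bromine and the hydroxy group in together, so these compounds cannot say whether either one alone would give the lower number, or whether the two are needed together. Going by these compounds, it also remains open how an aryl group carrying an amine or a carboxylic acid would read at this position, and whether a hydroxy group combined with chlorine instead of bromine would hold the step.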